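Methoxy for Methyl: A Step Expected to Stay Flat

This account rests on a few compounds, and the source may have more. Where it says the series, first, only, none or still open, it means among the compounds named here.

Compound 1 `Brc1ccc(NCc2nc3ccc(Br)cc3[nH]2)cc1` and compound 2 `Cc1ccc(NCc2nc3ccc(Br)cc3[nH]2)cc1` share one core and differ only in the group on the outer ring. In a functional assay on the whole organism (strain albino) for inhibition, with Rattus norvegicus as the target, read by paw edema, with a stated time of 180 min, at a dose of 100 mg/kg by the oral route (on this read-out lower numbers stand for less inhibition and higher numbers for more inhibition at the one dose given (going by the name of the read-out)), compound 1 gives 16.6% and compound 2 gives 16.6%, so compound 2 stands level with compound 1, the step being no change at the digits printed from compound 1 to compound 2 (within the scatter). Compound 3 `COc1ccc(NCc2nc3ccc(Br)cc3[nH]2)cc1` carries methoxy in place of methyl on an aromatic carbon, para to a large group. Among the compounds with values here, the only measured step, methyl in place of bromo, was flat, and no methoxy has yet been tested at this place; the expected step is therefore a number 0.4 percentage points higher from compound 2 to compound 3 (within the scatter), within the scatter. Compound 3 is estimated at 17%, in a range of 8% to 28%.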

Compound 3, a percentage reported as inhibition, in the whole organism at one dose (the size of the read-out at that dose, not a potency): 12.5%
Beside the measured number, compound 3's estimate is 4.5 percentage points above it, and the stated range covers the measured number.
By their numbers in this assay, from the lowest: compounds 3, 1 and 2 (each within the scatter of the next).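

In this assay methoxy in place of methyl gives a number 4.1 percentage points lower from compound 2 to compound 3 (within the scatter) and methoxy in place of bromo gives a number 4.1 percentage points lower from compound 1 to compound 3 (within the scatter) at this place. Within the data shown here, the first group here to bring an oxygen and a hydrogen-bond acceptor to the aromatic carbon para to a large group thus stays within the scatter of both earlier groups. Nothing measured here bears on the reason for this.

The compounds shown leave open whether an amine or a carboxylic acid at this place would step beyond the scatter. As far as these compounds go, a longer chain remains equally open.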